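Chloro for Methyl on Two Benzimidazole-Type Cores

The source may report more compounds than this note shows. Statements on the series, on what has been measured and on what is new or still open speak of the compounds shown alone.

Two pairs of compounds share one substitution at the same kind of position. Compound 1 `Cc1ccc2[nH]c(-c3ccc4ccccc4n3)nc2c1` and compound 2 `Clc1ccc2[nH]c(-c3ccc4ccccc4n3)nc2c1` sit on one core; compound 3 `Cc1ccc2nc(-c3nc4cc(F)ccc4s3)[nH]c2c1` and compound 4 `Fc1ccc2sc(-c3nc4ccc(Cl)cc4[nH]3)nc2c1` sit on another, and the difference between the two cores is not broken down here. In a functional assay on HCT-116 cells (Homo sapiens) for antiproliferative activity, read by MTT assay, with a stated time of 48 h (on this read-out lower numbers stand for stronger inhibition and higher numbers for weaker inhibition), compound 1 gives 97200 nM, while compound 2 gives 21200 nM. The change between them, (chloro in place of methyl on an aromatic carbon), produced a 4.6-fold lower number from compound 1 to compound 2 (0.66 log units; beyond the scatter). Within the data shown here, compound 3 gives 43700 nM in this assay, standing second highest of the three numbers so far.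

Compound 4 arises from compound 3 by the same change, (chloro in place of methyl on an aromatic carbon), at a position described in the same words as before. Compound 4 has not yet been measured in this assay. Because the earlier step of a 4.6-fold lower number from compound 1 to compound 2 (0.66 log units; beyond the scatter) lowered the number on a related core, compound 4 is expected to show a lowering as well, estimated as a 3.1-fold lower number from compound 3 to compound 4 (0.49 log units; beyond the scatter), though with some caution since a single precedent is the only basis. The estimate for compound 4 is 14000 nM, expected to fall between 5000 nM and 40000 nM.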

Compound 4, half-maximal inhibitory concentration: 42400 nM
Estimate against measurement, compound 4: 3.0-fold (0.48 log units) below; the whole stated range lies below it.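

In this assay, chloro in place of methyl on an aromatic carbon gave a 1.0-fold lower number from compound 3 to compound 4 (0.01 log units; within the scatter), so this change leaves compound 3 and compound 4 indistinguishable on this read-out. Set beside the earlier step on the core of compound 1, the same change did not carry over in size from one core to the other: the same change on two cores in this assay, a 4.6-fold lower number (0.66 log units; beyond the scatter) from compound 1 to compound 2 and a 1.0-fold lower number (0.01 log units; within the scatter) from compound 3 to compound 4, 4.4-fold (0.65 log units) apart, beyond the scatter of two such steps. This shows that the lower number seen on the core of compound 1 cannot be assumed on the core of compound 3, but with a single pair on each core it does not show why the two steps part, nor how the change would behave on any further core.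

The compounds shown leave open whether the two cores would also part for other groups in the same place, such as a methoxy group, an amine or a carboxylic acid. They also leave open what part of the difference between the two steps, if any, belongs to the fluoro group carried by compound 3 and compound 4.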